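Working notes: from compound 3 to compound 4

The compounds below may be only part of what the source reports. "The series", "measured", "known", "first", "only" and "open" are said of these compounds alone.

Measured in a functional assay on HepG2 cells (Homo sapiens) for inhibition, read by spectrophotometry, with stated times of 5 min and 1 h; a higher number here means a weaker inhibitor, a lower number a stronger inhibitor:
- Compound 1 `O=C(/C=C/c1ccc(O)c(O)c1)OC[C@H]1O[C@@]2(C(=O)O)C[C@@H](O)[C@@H](O)[C@@H]1O2`: > 100000 nM, a limit
- Compound 2 `O=C(/C=C/c1ccc(O)c(O)c1)OC[C@H]1O[C@@]2(C(=O)O)C[C@@H](OC(=O)/C=C/c3ccc(O)c(O)c3)[C@@H](O)[C@@H]1O2`: 79000 nM
- Compound 3 `COC(=O)[C@]12C[C@@H](O)[C@@H](O)[C@H](O1)[C@@H](COC(=O)/C=C/c1ccc(O)c(O)c1)O2`: 86000 nM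

Compound 3 at 86000 nM lies within the scatter of compound 2 at 79000 nM. The unmeasured compound 4 `COC(=O)[C@]12C[C@@H](OC(=O)/C=C/c3ccc(O)c(O)c3)[C@@H](O)[C@H](O1)[C@@H](COC(=O)/C=C/c1ccc(O)c(O)c1)O2` differs from compound 3 as follows: (2-(3,4-dihydroxyphenyl)ethenyl)carbonyl in place of hydrogen on an oxygen on a saturated carbon. The same exchange gave an at least 1.2-fold lower number from compound 1 to compound 2 (0.10 log units; that floor lies within the scatter). The methyl exchange gave an at least 1.1-fold lower number from compound 1 to compound 3 (0.06 log units; that floor lies within the scatter). Both steps are floors only, since they start from the limit of > 100000 nM in this assay, at which 1 of the 3 values shown sits. A small lowering in this assay is therefore expected, probably not beyond the scatter. The expected step is a 1.4-fold lower number from compound 3 to compound 4 (0.16 log units; within the scatter). The estimate for compound 4 is 60000 nM, with an expected range of 25000 nM to 120000 nM.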

Compound 4, half-maximal inhibitory concentration: 34500 nM
Estimate against measurement, compound 4: 1.7-fold (0.24 log units) above; measured number inside the range.
By their numbers in this assay, from the lowest: compound 4; then compounds 2 and 3 (each within the scatter of the next). At a limit, above all of these: compound 1.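

In this assay, (2-(3,4-dihydroxyphenyl)ethenyl)carbonyl in place of hydrogen on an oxygen on a saturated carbon now gives a step that is more than a floor: a 2.5-fold lower number from compound 3 to compound 4 (0.40 log units; beyond the scatter). Methyl in place of hydrogen on an oxygen next to a carbonyl group does the same, with a 2.3-fold lower number from compound 2 to compound 4 (0.36 log units; beyond the scatter). Each change thus lowers the number beyond the scatter when the other is already present.

From the compounds shown here alone, whether either step depends on the core stays open: the same change on two cores in this assay, an at least 1.1-fold lower number (0.06 log units; that floor lies within the scatter) from compound 1 to compound 3 and a 2.3-fold lower number (0.36 log units; beyond the scatter) from compound 2 to compound 4; the limit leaves it open whether they differ Also open is what an amine in place of the (2-(3,4-dihydroxyphenyl)ethenyl)carbonyl, or a longer chain in place of the methyl, would give.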